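A few compounds are considered here, and "the series" means these few. Any claim that something is new, unique, unknown or untested is made for them only; others in the source may bear on it.

Compound 3 `C=C(C)C/N=C(\NC#N)Nc1cccnc1` gives 20 mg/kg in a functional assay on the whole organism (blood, strain Wistar-Okamoto) with Rattus norvegicus as the target, with a stated time of 5 days; a higher number here means that more compound is needed for the effect, a lower number that less compound is needed. It stands level with compound 1 `CC(C)C/N=C(\NC#N)Nc1cccnc1`, which gives 20 mg/kg, and with compound 2 `CCC(CC)/N=C(\NC#N)Nc1cccnc1`, which gives 20 mg/kg; the steps of no change at the digits printed from compound 1 to compound 3 (within the scatter) and no change at the digits printed from compound 2 to compound 3 (within the scatter) both lie within the scatter. Compound 4 `N#CN/C(=N\c1ccccc1)Nc1cccnc1` has not yet been measured. It differs from compound 3 in one place: phenyl in place of 2-methylprop-2-en-1-yl on a double-bonded nitrogen. The measured steps that exchange the group on the double-bonded nitrogen, no change at the digits printed from compound 1 to compound 2 (within the scatter) and no change at the digits printed from compound 2 to compound 3 (within the scatter), were each flat, and no change at the digits printed from compound 1 to compound 3 (within the scatter) likewise stayed within the scatter. None of those exchanges brought in an aromatic ring, so the entry of phenyl reaches beyond what the three measured compounds cover. On that basis the expected step of no change at the digits printed from compound 3 to compound 4 (within the scatter) is none beyond the scatter, with a wider range allowed for the unfamiliar ring. Compound 4 is therefore estimated at 20 mg/kg, between 7 mg/kg and 60 mg/kg.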

Compound 4, minimum effective dose: 5 mg/kg
Beside the measured number, compound 4's estimate is 4.0-fold (0.60 log units) above it; the whole stated range lies above it.
By their numbers in this assay, from the lowest: compound 4; then compounds 1, 2 and 3 (each within the scatter of the next).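

Among these compounds, at the double-bonded nitrogen, isobutyl, pentan-3-yl and 2-methylprop-2-en-1-yl had given the same number in this assay, and phenyl is the first group there to move it beyond the scatter (a 4.0-fold lower number from compound 3 to compound 4 (0.60 log units; beyond the scatter)), (a 4.0-fold lower number from compound 2 to compound 4 (0.60 log units; beyond the scatter)) and (a 4.0-fold lower number from compound 1 to compound 4 (0.60 log units; beyond the scatter)). This position is therefore not indifferent to the group it carries, although the three non-aromatic groups did not reveal this. Compound 4, the only one of the four with a six-membered aromatic ring of carbon only, needs the least compound for the effect, and its steps to all three others lie beyond the scatter.

Whether the aromatic ring itself accounts for the lower number stays open, since a cyclohexyl group, a benzyl group or a phenyl ring bearing a methoxy group could separate the ring from its size and placement. Nothing available gives a reason for the step.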